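The compounds below may be only part of what the source reports. "The series", "measured", "known", "first", "only" and "open" are said of these compounds alone.

Measured in a functional assay on HCT-116 cells (Homo sapiens) for antiproliferative activity, read by CCK-8 assay, with a stated time of 72 h; a lower number here means a stronger inhibitor, a higher number a weaker inhibitor:
- compound 1 `CCOc1cc(C(C)(C)C)ccc1C1=NC(c2ccc(Cl)cc2)C(c2ccc(Cl)cc2)N1C(=O)NCCCCCCCC(=O)Nc1ccccc1N`: 9910 nM
- compound 2 `CCOc1cc(C(C)(C)C)ccc1C1=NC(c2ccc(Cl)cc2)C(c2ccc(Cl)cc2)N1C(=O)N1CCN(CCCCCC(=O)NO)CC1`: 4030 nM

Compound 1 gives 9910 nM, the higher of the two numbers, and compound 2 gives 4030 nM. The gap between them lies beyond the usual scatter, so compound 1 is the weaker of this pair.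

Compound 3 `CCOc1cc(C(C)(C)C)ccc1C1=NC(c2ccc(Cl)cc2)C(c2ccc(Cl)cc2)N1C(=O)NCCCCCCCC(=O)NO` has not yet been measured. It keeps the rest of compound 1 and changes one end group: hydroxy in place of 2-aminophenyl on an amide-type nitrogen. For the measured compounds named here, no measured pair differing in one place is available, so this change has no direct precedent in this assay.

Going by the values given here, the only indirect guide is compound 2, which also ends in hydroxycarbamoyl but differs from compound 3 elsewhere. Compound 2 reads 4030 nM, while compound 1 reads 9910 nM. A moderate move towards a lower number, beyond the scatter, is therefore expected, although this rests on thin evidence. The estimated step is a 3.3-fold lower number from compound 1 to compound 3 (0.52 log units; beyond the scatter). For compound 3 the estimated value is 3000 nM, with an expected range of 1000 nM to 8000 nM.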

Compound 3, half-maximal inhibitory concentration: 5030 nM
The estimate for compound 3 lay 1.7-fold (0.22 log units) below the measured number; the measured number falls inside the stated range.
By their numbers in this assay, from the lowest: compounds 2, 3 and 1 (each within the scatter of the next, the first and the last beyond it).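

In this assay, for the compounds shown here, the replacement of 2-aminophenyl by hydroxy on an amide-type nitrogen gives a 2.0-fold lower number from compound 1 to compound 3 (0.29 log units; within the scatter) and provides the first direct reading of this change. The same difference, read one bond further out as (2-aminophenyl)carbamoyl to hydroxycarbamoyl, therefore does not separate the two end groups in this read-out, even though the group leaving has 7 heavy atoms and a six-membered aromatic ring and the group entering has 1 heavy atom and no ring. No available measurement bears on why the two end groups read alike.

Going by these compounds, whether a carboxylic acid or a primary amide in place of hydroxycarbamoyl, or a shorter or longer chain carrying the same end group, would move the number beyond the scatter in this assay remains open. Compound 2 differs from compound 3 in more than one place, so the contribution of the chain and its attachment to the shared core cannot be read from the compounds shown.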